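Shortening the sulfonyl linker on the shared core

This account rests on a few compounds, and the source may have more. Where it says the series, first, only, none or still open, it means among the compounds named here.

Compound 1 `CS(=O)(=O)Cc1cccc(C#Cc2cc(Cl)ccc2OCC(=O)O)c1`: 48 nM
Compound 2 `Cc1ccc(S(=O)(=O)N(C)CC(C)C)cc1C#Cc1cc(Cl)ccc1OCC(=O)O`: 4.2 nM
Compound 3 `CC(C)c1ccc(S(C)(=O)=O)cc1C#Cc1cc(C#N)ccc1OCC(=O)O`: 12 nM

Of the compounds shown here, three have been tested in an assay on CHO cells for displacement of a labelled ligand from prostaglandin D2 receptor 2 (Homo sapiens), read by scintillation counting; on this read-out lower numbers stand for stronger inhibition and higher numbers for weaker inhibition. Compound 1 gives the highest of the three numbers; compound 3 lies nearer to it and compound 2 further away, both steps reaching beyond the usual scatter. Compound 2 carries a sulfonamide on its aryl ring and compound 3 a methylsulfonyl; in compound 1 the sulfonyl group is set off from the ring by a single carbon.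

Compound 4 `CS(=O)(=O)c1cccc(C#Cc2cc(Cl)ccc2OCC(=O)O)c1` has not yet been measured in this assay. It differs from compound 1 in one place: methylsulfonyl in place of (methylsulfonyl)methyl on an aromatic carbon, on an aromatic carbon of a six-membered aromatic ring of carbon only, meta to a large group.

Among the measured compounds shown here, no measured pair shows this exact change. Compound 4 is expected to move in the direction of compound 3, which gives 12 nM in this assay, so a step of about a 3.2-fold lower number from compound 1 to compound 4 (0.51 log units; beyond the scatter) toward stronger binding is expected. The estimate for compound 4 is 15 nM, with a range from 5 nM to 50 nM.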

Compound 4, inhibition constant: 15 nM
Compound 4: middle estimate and measured number agree at the digits printed; low and high end bracket the measured number.
By their numbers in this assay, from the lowest: compound 2; then compounds 3 and 4 (each within the scatter of the next); then compound 1.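

In this assay, among the compounds shown here, taking out the single carbon between the ring and the sulfonyl gives a 3.2-fold lower number from compound 1 to compound 4 (0.51 log units; beyond the scatter) as a modest step toward stronger binding, the first comparison here in which only one place differs. On the shared core, methylsulfonyl on this aromatic carbon, meta to a large group, therefore gives a lower number than (methylsulfonyl)methyl, even though the two groups have the same hydrogen-bond donor and acceptor counts. No measurement at hand accounts for this step.

The compounds shown leave open how a longer chain between the ring and the sulfonyl would read, and whether an amine or an amide at this carbon would keep the lower number. They also leave open whether the same change would give a step of similar size at another carbon of this ring.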